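The source may hold more compounds than are shown below. What is called first, only, known or untested is meant among the compounds shown, and "the series" means these compounds.

Measured so far in a functional assay on HCT-116 cells (Homo sapiens) for inhibition, read by MTT assay, with a stated time of 72 h; on this read-out lower numbers stand for stronger inhibition of growth and higher numbers for weaker inhibition of growth:
- compound 1, `O=C(/C=C/c1ccncc1-c1ccc2ccccc2c1)NC1CC1`: 6180 nM
- compound 2, `NNC(=O)CCc1ccncc1-c1ccc2ccccc2c1`: a value given only as a limit of the assay, > 30000 nM
- compound 3, `COC(=O)COc1ccncc1-c1ccc2ccccc2c1`: "not determined" (no result reported)

Compound 3 therefore stands nowhere on the numbers shown: for it this assay gives no result, and the only other entry besides the number for compound 1 is the limit (the limit of > 30000 nM in this assay, at which 1 of the 3 values shown sits), which belongs to compound 2. Compound 4, `CN(C)C(=O)/C=C/c1ccncc1-c1ccc2ccccc2c1`, differs from compound 3 in one place, (2-(dimethylcarbamoyl)ethenyl in place of (methoxycarbonyl)methoxy on an aromatic carbon).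

For the measured compounds named here, only one measured step exists, an at least 4.8-fold higher number from compound 1 to compound 2 (0.68 log units; beyond the scatter). It shows that exchanging the 2-(cyclopropylcarbamoyl)ethenyl group for 2-(aminocarbamoyl)ethyl weakens growth inhibition at least modestly. Compound 4 carries a 2-(dimethylcarbamoyl)ethenyl group, which keeps the ethenyl chain and the carbamoyl of compound 1 and changes only the substituents on the amide nitrogen. Since the step from compound 3 cannot be sized, the reference point for compound 4 is what compound 1 shows in this assay, with no step beyond the scatter foreseen between the two amides, in either direction. Compound 4 is thus expected to give about 6500 nM in this assay, estimated to lie between 2000 nM and 22000 nM.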

Compound 4, concentration for 50% growth inhibition: 4540 nM
Beside the measured number, compound 4's estimate is 1.4-fold (0.16 log units) above it; the range from low to high includes it.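

In this assay, dimethylamino in place of cyclopropylamino on the carbonyl carbon gives a 1.4-fold lower number from compound 1 to compound 4 (0.13 log units; within the scatter), so at this position, opposite the ring nitrogen, the two ethenyl amides read alike. With 2-(dimethylcarbamoyl)ethenyl in place of 2-(aminocarbamoyl)ethyl, the reading is an at least 6.6-fold lower number from compound 2 to compound 4 (0.82 log units; beyond the scatter), so the separation first seen with the cyclopropyl amide appears again with a second amide. This step is a bound rather than a size, since compound 2 stands at a limit of the assay: the limit of > 30000 nM in this assay, at which 1 of the 4 values shown sits.

The 2-(aminocarbamoyl)ethyl group differs from both ethenyl amide groups in the chain and in the group on the carbonyl at once, and the compounds shown do not separate these two changes. For the compounds shown here, it also remains open how a carboxylic acid or a primary amide on the ethenyl chain, or a longer chain, would read, and no step involving compound 3 can be read, as it has no result.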